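From phenyl to 4-fluorophenyl in a cell growth assay

The source may hold more compounds than are shown below. What is called first, only, known or untested is meant among the compounds shown, and "the series" means these compounds.

Compound 1 `COc1cc(-n2ncnc2-c2ccc(Cl)c(Cl)c2)cc(OC)c1OC`: > 10000 nM (a limit)
Compound 2 `CCOc1ccc(-c2ncnn2-c2cc(OC)c(OC)c(OC)c2)cc1`: 100 nM
Compound 3 `COc1cc(-n2ncnc2-c2ccccc2)cc(OC)c1OC`: > 10000 nM (a limit)
Compound 4 `COc1cc(-n2ncnc2-c2ccc(F)cc2)cc(OC)c1OC`: not yet measured

In a functional assay on A549 cells (Homo sapiens) for antiproliferative activity, read by MTT assay, with a stated time of 72 h (on this read-out lower numbers stand for stronger inhibition and higher numbers for weaker inhibition), compound 3 gives > 10000 nM, which is a limit and not a number. Compound 1 and compound 3 share (the limit of > 10000 nM in this assay, at which 2 of the 3 values shown sit), so only compound 2 has a true number.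

Compound 4 differs from compound 3 by fluoro in place of hydrogen on an aromatic carbon.

Going by the values given here, two measured steps bear on this change. The step of an at least 100-fold higher number from compound 2 to compound 3 (2.00 log units; beyond the scatter) is large and shows that a group at this place can matter. Fluoro is not ethoxy, however, so that size need not carry over. The step that the two limits leave unreadable from compound 1 to compound 3 gives no size, and compound 1 keeps its limit of > 10000 nM even with 3,4-dichlorophenyl on the ring.

Compound 4 is therefore expected to stay weak in this assay, most likely at the same limit. The expected change is a number no higher from compound 3 to compound 4 (the limit leaves the size open), with no step beyond the scatter anticipated. For compound 4 the estimate is 10000 nM, with an expected range from 2000 nM to 30000 nM.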

Compound 4, half-maximal inhibitory concentration: > 10000 nM
Compound 4 was reported as a limit; the forecaster's own chance of this, stated with the estimate: 65%; the middle value lies on the limit itself.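

In this assay compound 4 gives > 10000 nM, which is a limit and not a number. Fluoro in place of ethoxy at this place gives an at least 100-fold higher number from compound 2 to compound 4 (2.00 log units; beyond the scatter), so a single fluorine on the ring does not restore the activity seen with ethoxy. The steps linking compound 1, compound 3 and compound 4 cannot be read, and only compound 2 has a true number so far: the limit of > 10000 nM in this assay, at which 3 of the 4 values shown sit.

On these data alone, how far compound 1, compound 3 and compound 4 differ from one another remains open, as does the question of which part of ethoxy matters. A methoxy group, an ethyl group or a longer propoxy chain at this place would help to separate the role of the oxygen from that of the chain.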